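The source may hold more compounds than are shown below. What is called first, only, known or untested is meant among the compounds shown, and "the series" means these compounds.

Measured compounds:
- compound 1 `Cc1cc(-c2ccccc2)n2nc(C(=O)Nc3ccsc3C(N)=O)nc2n1`: 250000 nM
- compound 2 `Cc1cc(-c2ccccc2)n2nc(C(=O)Nc3ccccc3C(N)=O)nc2n1`: a limit of > 250000 nM
- compound 3 `Cc1cc(-c2ccccc2)nc2nc(C(=O)Nc3ccsc3C(N)=O)nn12`: 240000 nM

Compound 1 and compound 3 share the same atoms joined differently; the difference between the two cores is not broken down here. In an ADME assay on MDCK cells (Canis lupus familiaris) for cytotoxicity, read by MTT assay, with a stated time of 48 h (a lower number here means that less compound is tolerated, a higher number that more compound is tolerated), compound 1 gives 250000 nM. In this assay compound 3 gives 240000 nM, which sits within the scatter of compound 1, so no order between the two is read. Compound 2 differs from compound 1 by 2-carbamoylphenyl in place of 2-carbamoylthiophen-3-yl on an amide-type nitrogen. In this assay compound 2 reaches a limit rather than a number. As far as these compounds go, the size of the step of a number no lower from compound 1 to compound 2 (the limit leaves the size open) stays open because of the limit of > 250000 nM in this assay, at which 1 of the 3 values shown sits.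

Compound 4 `Cc1cc(-c2ccccc2)nc2nc(C(=O)Nc3ccccc3C(N)=O)nn12` is the matching partner of compound 3: 2-carbamoylphenyl in place of 2-carbamoylthiophen-3-yl on an amide-type nitrogen. The place of the change is worded the same in both pairs, so it is the same change. The step from compound 3 is expected to be open in size beside the earlier one, resting on the step of a number no lower from compound 1 to compound 2 (the limit leaves the size open). The expected step is a 1.0-fold higher number from compound 3 to compound 4 (0.02 log units; within the scatter). For compound 4 in this assay the estimate is 250000 nM, between 150000 nM and 400000 nM, most likely reported as a limit.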

Compound 4, half-maximal cytotoxic concentration: > 250000 nM
Compound 4: only a limit was reported; the forecaster's own chance of this, stated with the estimate: 60%; the middle value sits exactly at the limit.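

In this assay compound 4 is reported only as a limit, > 250000 nM. The step therefore has a floor and no measured size, reading as an at least 1.0-fold higher number from compound 3 to compound 4 (0.01 log units; that floor lies within the scatter), and when it is set beside the step on the other core the result is: the same change on two cores in this assay, a number no lower (the limit leaves the size open) from compound 1 to compound 2 and an at least 1.0-fold higher number (0.01 log units; that floor lies within the scatter) from compound 3 to compound 4; the limit leaves it open whether they differ The change carries over between the two cores only in that neither core gives a lower number with 2-carbamoylphenyl, and this does not show that the size of the step is the same on both cores: the limit of > 250000 nM in this assay, at which 2 of the 4 values shown sit.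

The compounds shown leave open how the numbers in this assay would respond to another group in place of the carbamoyl group on either aromatic ring, such as a carboxylic acid, an amine or a nitrile. Also open, as far as these compounds go, is the actual size of the step on each core, as both compound 2 and compound 4 stand at a limit rather than at a number.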